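The compounds below may be only part of what the source reports. "The series", "measured", "known", "first", "only" and "open" are said of these compounds alone.

Three close relatives sharing one core have been tested in a functional assay on MKN-45 cells (Homo sapiens) for cytotoxicity, read by MTT assay, with a stated time of 72 h; on this read-out lower numbers stand for stronger inhibition and higher numbers for weaker inhibition. Compound 1 `CN(C)CCn1cnnc1-c1cc(Oc2ccc(NC(=O)N/N=C/c3ccc(O)c(F)c3)cc2F)ccn1` gives 1970 nM, the highest number of the three. Compound 2 `CN(C)CCn1cnnc1-c1cc(Oc2ccc(NC(=O)N/N=C/c3ccccc3O[N+](=O)[O-])cc2F)ccn1` gives 1020 nM, and compound 3 `CN(C)CCn1cnnc1-c1cc(Oc2ccc(NC(=O)N/N=C/c3ccc(F)cc3F)cc2F)ccn1` gives 810 nM. The measured steps are a 1.9-fold lower number from compound 1 to compound 2 (0.29 log units; within the scatter), a 2.4-fold lower number from compound 1 to compound 3 (0.39 log units; beyond the scatter) and a 1.3-fold lower number from compound 2 to compound 3 (0.10 log units; within the scatter). Compound 4 `CN(C)CCn1cnnc1-c1cc(Oc2ccc(NC(=O)N/N=C/c3ccc(O)cc3O)cc2F)ccn1` differs from compound 1 at that same carbon: 2,4-dihydroxyphenyl in place of 3-fluoro-4-hydroxyphenyl on a carbon with a double bond to nitrogen. Among the compounds with values here, no measured step brings in a 2,4-dihydroxyphenyl, so the two steps away from compound 1 offer only a loose guide; both lowered the number, one of them modestly. The expected step is therefore small, downward or none beyond the scatter: a 1.3-fold lower number from compound 1 to compound 4 (0.12 log units; within the scatter). Compound 4 is estimated at 1500 nM, within 600 nM to 3800 nM.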

Compound 4, half-maximal inhibitory concentration: 2860 nM
For compound 4 the middle estimate is 1.9-fold (0.28 log units) below the measured one; low and high end bracket the measured number.
By their numbers in this assay, from the lowest: compounds 3, 2, 1 and 4 (each within the scatter of the next, the first and the last beyond it).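

Compound 1 and compound 4, the two that carry a hydroxyl on this phenyl, show a 1.5-fold higher number from compound 1 to compound 4 (0.16 log units; within the scatter). Unlike compound 1, compound 4 stands clear of both other groups at this carbon, with a 2.8-fold higher number from compound 2 to compound 4 (0.45 log units; beyond the scatter) and a 3.5-fold higher number from compound 3 to compound 4 (0.55 log units; beyond the scatter). Nothing available explains these steps. Still open, going by these compounds, is where a plain phenyl would fall relative to compound 4, and the same goes for a phenyl carrying an amine or a carboxylic acid.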